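The compounds below may be only part of what the source reports. "The series", "measured", "known", "first", "only" and "open" are said of these compounds alone.

For the measured compounds named here, compound 1 `COc1cc(N2CCN(S(C)(=O)=O)CC2)ccc1Nc1ncc2ccn(C3CCCCC3)c2n1` holds the lower of the two numbers so far: in a functional assay on HCT-116 cells (Homo sapiens) for cytotoxicity (a higher number here means a weaker inhibitor, a lower number a stronger inhibitor), compound 1 gives 750 nM, while compound 2 `COc1cc(N2CCN(S(C)(=O)=O)CC2)ccc1Nc1nccc(N(C)C2CCCCC2)n1` gives 2000 nM, a gap beyond the scatter. Compound 3 `COc1cc(N2CCN(S(C)(=O)=O)CC2)ccc1Nc1ncc2ccn(-c3ccccn3)c2n1` differs from compound 1 by pyridin-2-yl in place of cyclohexyl on an aromatic nitrogen, pyridin-2-yl taking the place of cyclohexyl on an aromatic nitrogen of the five-membered ring of the fused system. Going by the values given here, no measured pair covers this change, so its size is unknown; a small weakening, not clearly beyond the scatter, is expected, a 1.5-fold higher number from compound 1 to compound 3 (0.17 log units; within the scatter). Compound 3 is therefore estimated at 1100 nM, within the range 300 nM to 4000 nM.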

Compound 3, half-maximal inhibitory concentration: 10000 nM
Estimate against measurement, compound 3: 9.1-fold (0.96 log units) below; measured number outside the range, above it.
By their numbers in this assay, from the lowest: compound 1; then compound 2; then compound 3.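

At the aromatic nitrogen of the five-membered ring, the group carried matters strongly: in this assay, pyridin-2-yl in place of cyclohexyl gives a 13-fold higher number from compound 1 to compound 3 (1.12 log units; beyond the scatter). Two groups with the same heavy-atom count thus separate widely, as a non-aromatic carbon ring gives way to an aromatic ring with one nitrogen and one hydrogen-bond acceptor. No available evidence bears on the cause of this step. Still open, on these data alone, is whether the aromatic ring itself or its nitrogen accompanies the step; phenyl at this position would separate the two, and isopropyl would test a smaller non-aromatic group.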